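A fluorocyclopropyl amide on a bicyclic diamine core

The source may hold more compounds than are shown below. What is called first, only, known or untested is meant among the compounds shown, and "the series" means these compounds.

Measured so far in an assay on CHO cells for displacement of a labelled ligand from Neuronal acetylcholine receptor; alpha3/alpha6/beta2/beta3 (Homo sapiens), read by scintillation counting; a lower number here means a stronger inhibitor, a higher number a weaker inhibitor:
compound 1 `CC(=O)N1CC2CC(C1)N2`: 610 nM
compound 2 `O=C(C1CC=CC1)N1CC2CC(C1)N2`: 1100 nM

Compound 1 gives the lower of the two numbers, yet compound 2 lies within the usual scatter of it, so the two cannot be told apart. Compound 3 `O=C([C@H]1C[C@H]1F)N1CC2CC(C1)N2` differs from compound 1 in one place: 2-fluorocyclopropyl in place of methyl on a carbonyl carbon. Among the compounds with values here, no measured pair shows such a step, so the expectation rests on the two values alone. Because compound 2, with a larger ring on the same carbonyl carbon, gives 1100 nM, the step from compound 1 to compound 3 in this assay is expected to be small, a 1.2-fold higher number from compound 1 to compound 3 (0.09 log units; within the scatter), not beyond the scatter. Compound 3 is therefore estimated at 750 nM, within a range from 250 nM to 2300 nM.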

Compound 3, inhibition constant: 27 nM
For compound 3 the middle estimate is 28-fold (1.44 log units) above the measured one; the measured number lies below the stated range.
By their numbers in this assay, from the lowest: compound 3; then compounds 1 and 2 (each within the scatter of the next).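

In this assay the group on the carbonyl carbon turns out to matter a great deal: 2-fluorocyclopropyl in place of methyl gives a 23-fold lower number from compound 1 to compound 3 (1.35 log units; beyond the scatter) and is well beyond the scatter. Within the data shown here, the values of compound 1 and compound 2 alone gave no sign that one change here could move the number so far. Nothing measured here explains this gain. The compounds shown leave open whether the fluorine, the three-membered ring or both account for it; a plain cyclopropyl on the same carbonyl carbon would separate these possibilities.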